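The compounds below may be only part of what the source reports. "The series", "measured", "known", "first", "only" and "open" are said of these compounds alone.

Of the compounds shown here, three have been tested in an in vitro assay on BTI-TN-5B1-4 cells for inhibition of Amine oxidase [flavin-containing] B (Homo sapiens), tested at 100 uM; a higher number here means more inhibition at the concentration tested (going by the name of the read-out), a lower number less inhibition. Compound 1, with the structure `Cc1ccc2c(=S)cc(-c3ccc(F)cc3)oc2c1`, gives 40% in this assay. Compound 2, `Cc1ccc(-c2cc(=O)c3ccc(C)cc3o2)cc1`, gives 40%, and compound 3, `COc1ccc(-c2cc(=O)c3ccc(C)cc3o2)cc1`, gives 40%. The three values stand level with one another within the scatter of the measurement, so no order among them can be read from these figures.

Compounds 2 and 3 differ in one place: methoxy in place of methyl on an aromatic carbon. This step, no change at the digits printed from compound 2 to compound 3 (within the scatter), leaves the read-out where it was. Compound 1 is built on a different core from compound 2; the difference between the two cores is not broken down here, and the two values simply sit level.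

Compound 4, `COc1ccc2c(=S)cc(-c3ccc(F)cc3)oc2c1`, has not yet been measured. It is related to compound 1 by the same kind of change that relates compound 2 to compound 3: methoxy in place of methyl on an aromatic carbon. The surroundings are not the same, however. In the step from compound 2 to compound 3 the change sits para to a large group, while in compound 4 it sits on a ring that is part of a fused or bridged system of two rings, meta to a fused ring and para to a fused ring. Because the earlier step of no change at the digits printed from compound 2 to compound 3 (within the scatter) produced no change within the scatter, compound 4 is expected to give a step of no change at the digits printed from compound 1 to compound 4 (within the scatter) from compound 1. The estimate for compound 4 in this assay is 40%, with a range from 25% to 55%.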

Compound 4, a percentage reported as inhibition, at one concentration (the size of the read-out at that concentration, not a potency): 40%
Beside the measured number, compound 4's estimate shows no gap at the digits printed, and the stated range covers the measured number.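

Set on the core of compound 1, methoxy in place of methyl on an aromatic carbon gives no change at the digits printed from compound 1 to compound 4 (within the scatter) in this assay. Set beside the same change on the other core, the new step does not differ from the earlier one: the same change on two cores in this assay, no change at the digits printed (within the scatter) from compound 2 to compound 3 and no change at the digits printed (within the scatter) from compound 1 to compound 4, 0 percentage points apart, within the scatter of two such steps

Across these two pairs, then, the change carries from one core to the other without moving the read-out, although it sits in a different place on each core. Among these compounds, this rests on only two pairs, each read at a single concentration, so it shows that the swap made no visible difference under these conditions, not that the two groups are interchangeable in potency or that the same would hold on any further core.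

The compounds shown carry only methyl or methoxy at the site of this change, so the effect of an amine, a carboxylic acid or a longer chain such as ethoxy there remains open. Also open is what sulfur in place of the carbonyl oxygen does on its own, since no pair shown differs in that one place alone.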